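The source may hold more compounds than are shown below. What is called first, only, known or untested is meant among the compounds shown, and "the series" means these compounds.

Values in an ADME assay on HEK293 cells (Homo sapiens) for cytotoxicity, read by MTT assay, with a stated time of 24 h (on this read-out lower numbers stand for stronger inhibition and higher numbers for weaker inhibition), so far

compound 1 `CN(C)CCCNc1nc2cc([N+](=O)[O-])ccc2nc1NCc1ccc(C(F)(F)F)cc1`: 5.66 ug/mL
compound 2 `Cc1ccc(CNc2nc3ccc([N+](=O)[O-])cc3nc2NCCCN(C)C)cc1`: 15.8 ug/mL

Among the measured compounds shown here, of the two numbers in this assay, the higher belongs to compound 2 at 15.8 ug/mL, and compound 1 is its only neighbour. Compound 3 `Cc1ccccc1CNc1nc2ccc([N+](=O)[O-])cc2nc1NCCCN(C)C` has not been measured. Its difference from compound 2 is 2-methylphenyl in place of 4-methylphenyl on a saturated chain carbon bound to a nitrogen on an aromatic ring, so the two have the same atoms, joined differently, with 2-methylphenyl in place of 4-methylphenyl.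

For the measured compounds named here, only one measured step is available, a 2.8-fold higher number from compound 1 to compound 2 (0.45 log units; beyond the scatter). It is modest, though beyond the scatter, and it replaces trifluoromethyl with methyl, which is a different kind of change. It therefore gives only a rough scale for a single change in this part of the molecule. Going by the values given here, no measured pair shows a change of the kind made in compound 3, so the direction remains open. No shift beyond the scatter is expected, and the estimated step is a 1.1-fold lower number from compound 2 to compound 3 (0.05 log units; within the scatter), with a step of the modest size seen above still possible. For compound 3 the expected value is 14 ug/mL, with an estimated range of 6 ug/mL to 32 ug/mL.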

Compound 3, half-maximal inhibitory concentration: 27.6 ug/mL
Estimate against measurement, compound 3: 2.0-fold (0.29 log units) below; the measured number falls inside the stated range.
By their numbers in this assay, from the lowest: compound 1; then compounds 2 and 3 (each within the scatter of the next).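

In this assay, 2-methylphenyl in place of 4-methylphenyl on a saturated chain carbon bound to a nitrogen on an aromatic ring gives a 1.7-fold higher number from compound 2 to compound 3 (0.24 log units; within the scatter), so this isomer pair provides the series' first read on moving the methyl, and the two compounds are not separated here. Against that, 2-methylphenyl in place of 4-(trifluoromethyl)phenyl gives a 4.9-fold higher number from compound 1 to compound 3 (0.69 log units; beyond the scatter), which leaves compound 1 apart from both methyl compounds, with its steps to each printed as beyond the scatter. No measurement at hand explains either step.

The compounds shown leave open whether the separation of compound 1 is particular to trifluoromethyl or would also appear with another group at this place, such as 4-chlorophenyl or 4-methoxyphenyl. They also leave open whether the same small isomer step would hold for 2-(trifluoromethyl)phenyl, and how any of these steps would carry over if a morpholine replaced the dimethylamino group at the end of the chain.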